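A Hydroxy for Methoxy in a Pair of Weak Inhibitors

The source may report more compounds than this note shows. Statements on the series, on what has been measured and on what is new or still open speak of the compounds shown alone.

In a physicochemical assay, read by spectrophotometry, with a stated time of 6 min (a lower number here means a stronger inhibitor, a higher number a weaker inhibitor), compound 1 (`O=C(CCCc1nc2ccccc2c(=O)[nH]1)N/N=C/c1ccc([N+](=O)[O-])cc1`) gives 270000000 nM and compound 2 (`COc1ccc(/C=N/NC(=O)CCCc2nc3ccccc3c(=O)[nH]2)cc1`) gives 180000000 nM. These two numbers lie within the usual scatter of repeated measurements, so neither compound can be ranked ahead of the other.

Compound 3 (`O=C(CCCc1nc2ccccc2c(=O)[nH]1)N/N=C/c1ccc(O)cc1`) is compound 2 with one small edit: hydrogen in place of methyl on an oxygen on an aromatic ring. It has hydrogen in place of methyl on an oxygen on an aromatic ring, so methoxy becomes hydroxy.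

Going by the values given here, only one measured step bears on this edit. In a 1.5-fold lower number from compound 1 to compound 2 (0.18 log units; within the scatter), methoxy takes the place of nitro on an aromatic carbon, and that large change of group leaves the number within the scatter. Among the compounds with values here, this is thin evidence, since no compound with a hydroxy group has been measured yet and a single step shows no trend. Even so, it gives no reason to expect a real shift in this assay from a smaller edit.

The estimated step, a 1.1-fold higher number from compound 2 to compound 3 (0.05 log units; within the scatter), is expected to stay within the scatter. For compound 3 the estimate is 200000000 nM, with an expected range from 90000000 nM to 400000000 nM.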

Compound 3, half-maximal inhibitory concentration: 170000000 nM
Compound 3: middle estimate off by 1.2-fold (0.07 log units), on the high side, within the range that was stated.
By their numbers in this assay, from the lowest: compounds 3, 2 and 1 (each within the scatter of the next).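

Putting hydrogen in place of methyl on the oxygen on the aromatic ring, so that methoxy becomes hydroxy, gives a 1.1-fold lower number from compound 2 to compound 3 (0.02 log units; within the scatter) in this assay, which shows that this small edit leaves the reading within the scatter. Hydroxy in place of nitro on the aromatic carbon gives a 1.6-fold lower number from compound 1 to compound 3 (0.20 log units; within the scatter), so the three groups now seen here, nitro, methoxy and hydroxy, cannot be ranked against each other, whereas the earlier compounds offered only the single comparison of nitro with methoxy. No separate measurement accompanies these numbers, so nothing explains why the three compounds read alike.

The compounds shown do not tell whether a different group on this aromatic carbon, such as an amine, a carboxylic acid or a longer chain joined through the oxygen, would give a reading beyond the scatter. They also leave open whether an edit elsewhere, in the shared core or in the chain that leads to it, would separate compounds that this position does not.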